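The source may report more compounds than this note shows. Statements on the series, on what has been measured and on what is new or still open speak of the compounds shown alone.

Of the compounds shown here, three built on one shared core have been measured in an assay on isolated protein for agonist activity at Free fatty acid receptor 1 (Homo sapiens); on this read-out higher numbers stand for an effect only at larger amounts of compound and lower numbers for an effect already at smaller amounts. Compound 1 `CC#CC(CC(=O)O)c1ccc(OCc2ccc3nc(-c4ccc(CC)cc4)cn3c2)cc1` gives 496 nM, compound 2 `CC#CC(CC(=O)O)c1ccc(OCc2ccc3nc(-c4ccc(C(F)(F)F)cc4)cn3c2)cc1` gives 558 nM, and compound 3 `CC#CC(CC(=O)O)c1ccc(OCc2ccc3nc(-c4ccc(OC)cc4)cn3c2)cc1` gives 47 nM. Compound 3 stands lowest of the three: an 11-fold lower number from compound 1 to compound 3 (1.02 log units; beyond the scatter) and a 12-fold lower number from compound 2 to compound 3 (1.07 log units; beyond the scatter), whereas a 1.1-fold higher number from compound 1 to compound 2 (0.05 log units; within the scatter). Compound 4 `CC#CC(CC(=O)O)c1ccc(OCc2ccc3nc(-c4ccccc4)cn3c2)cc1` has not yet been measured in this assay. It differs from compound 3 in one place: hydrogen in place of methoxy on an aromatic carbon. Within the data shown here, no measured step exchanges a methoxy for hydrogen, so the change can only be judged indirectly, through the two large steps that lead to compound 3. Because an 11-fold lower number from compound 1 to compound 3 (1.02 log units; beyond the scatter) and a 12-fold lower number from compound 2 to compound 3 (1.07 log units; beyond the scatter), taking the methoxy away is expected to move the number back up, although hydrogen brings no heavy atom, unlike the ethyl and trifluoromethyl of those steps, so the size of the step is uncertain. For compound 4 the expected change is a 6.4-fold higher number from compound 3 to compound 4 (0.81 log units; beyond the scatter). Compound 4 is estimated at 300 nM, with a range from 100 nM to 1000 nM.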

Compound 4, half-maximal effective concentration: 979 nM
Estimate against measurement, compound 4: 3.3-fold (0.51 log units) below; the measured number falls inside the stated range.
By their numbers in this assay, from the lowest: compound 3; then compounds 1, 2 and 4 (each within the scatter of the next).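

In this assay, hydrogen now gives a direct baseline at this place on the ring: taking away the methoxy gives a 21-fold higher number from compound 3 to compound 4 (1.32 log units; beyond the scatter), so the low number of compound 3 is a gain of 4-methoxyphenyl over phenyl. Ethyl and trifluoromethyl show no such gain, with a 2.0-fold higher number from compound 1 to compound 4 (0.30 log units; within the scatter) and a 1.8-fold higher number from compound 2 to compound 4 (0.24 log units; within the scatter), so neither group can be told apart from hydrogen here. Nothing available explains why the methoxy alone stands apart.

As far as these compounds go, whether a hydroxy group, an ethoxy group or a fluorine atom at this place would keep the low number of compound 3 stays open. Also open, from the compounds shown here alone, is whether a methoxy at another place on the ring would give a step of similar size.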